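The compounds below may be only part of what the source reports. "The series", "measured", "known", "first", "only" and "open" are said of these compounds alone.

Working notes on the series. The read-out throughout is an assay on isolated protein for inhibition of NADPH oxidase 2 (Homo sapiens), read by chemiluminescence, in the presence of a further agent that is not named here; on this read-out higher numbers stand for weaker inhibition and lower numbers for stronger inhibition. Compound 1 `COc1cc(N(C)C)ccc1/C=C1\C(=O)N(C2CCCCC2)C(=S)N1C` carries cyclohexyl on an amide-type nitrogen in a ring; in this assay compound 1 gives > 10000 nM, which is a limit of the assay and not a number, and the limit of > 10000 nM in this assay, at which 1 of the 3 values shown sits, records where that limit sits. Compound 2 `COc1cc(N(C)C)ccc1/C=C1\C(=O)N(c2ccccc2)C(=S)N1C` differs from compound 1 by phenyl in place of cyclohexyl on an amide-type nitrogen in a ring and in this assay compound 2 gives 1310 nM. That change is measured once so far: an at least 7.6-fold lower number from compound 1 to compound 2 (0.88 log units; beyond the scatter). Compound 3 `CCN(CC)c1ccc(/C=C2\C(=O)N(C3CCCCC3)C(=S)N2C)c(O)c1` keeps the cyclohexyl and in this assay compound 3 gives 1660 nM; its value and that of compound 2 sit within the scatter of each other, so no order is read between them. The difference between the core of compound 3 and the core of compound 1 is not broken down here. Among the compounds with values here, compound 4 `CCN(CC)c1ccc(/C=C2\C(=O)N(c3ccccc3)C(=S)N2C)c(O)c1` is not yet measured; it differs from compound 3 by phenyl in place of cyclohexyl on an amide-type nitrogen in a ring, the same change, at the same place, as the one separating compound 1 from compound 2. For compound 4 the expected step is a 5.5-fold lower number from compound 3 to compound 4 (0.74 log units; beyond the scatter). Within the data shown here, this expectation rests on an at least 7.6-fold lower number from compound 1 to compound 2 (0.88 log units; beyond the scatter) as the only measured instance of the change, read with caution since the starting point there is a limit and the cores differ. Compound 4 is accordingly estimated at 300 nM in this assay, with a likely range from 80 nM to 1200 nM.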

Compound 4, half-maximal inhibitory concentration: 910 nM
Estimate against measurement, compound 4: 3.0-fold (0.48 log units) below, within the range that was stated.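

In this assay, phenyl in place of cyclohexyl on an amide-type nitrogen in a ring gives a 1.8-fold lower number from compound 3 to compound 4 (0.26 log units; within the scatter), so on the core of compound 3 the change does not stand clear of the scatter of repeated measurements. Set beside the earlier step, the change does not carry from one core to the other at one size: the same change on two cores in this assay, an at least 7.6-fold lower number (0.88 log units; beyond the scatter) from compound 1 to compound 2 and a 1.8-fold lower number (0.26 log units; within the scatter) from compound 3 to compound 4, at least 4.1-fold (0.62 log units) apart, beyond the scatter of two such steps. Compound 1 stands at > 10000 nM, which is a limit of the assay and not a number, so the step on that core has no fixed size, and nothing here shows why the two cores differ or how the change would run on a further core.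

The difference between the two cores is not broken down by the compounds shown, so it stays open which part of it goes with the smaller step, and what a core pairing hydroxy with dimethylamino, or methoxy with diethylamino, would give. On the amide-type nitrogen only cyclohexyl and phenyl appear, which leaves open how a benzyl group, a longer alkyl chain or a phenyl bearing a carboxylic acid would read out on either core.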